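From compound 2 to compound 4: one change in cytotoxicity

This account rests on a few compounds, and the source may have more. Where it says the series, first, only, none or still open, it means among the compounds named here.

Of the compounds shown here, three built on the same core have been tested in an ADME assay on L6 cells (Rattus norvegicus) for cytotoxicity, read by resazurin assay, with a stated time of 70 h; a lower number here means a stronger inhibitor, a higher number a weaker inhibitor. Compound 1 `COc1cc(NC(C)CCCNC(=O)NCCNC(c2ccccc2)(c2ccccc2)c2ccccc2)c2ncccc2c1` carries a long chain ending in a trityl-type group; in this assay compound 1 gives > 171000 nM, which is a limit of the assay rather than a number. Compound 3 `COc1cc(NC(C)CCCNC(=O)NNC(=O)/C=C/c2cc(C(F)(F)F)cc(C(F)(F)F)c2)c2ncccc2c1` carries two trifluoromethyl groups on its outer ring; in this assay compound 3 gives > 170000 nM, again a limit and not a number. Compound 2 `COc1cc(NC(C)CCCNC(=O)NNC(=O)/C=C/c2ccc(Cl)cc2)c2ncccc2c1` is the only one of the three with a measured number: in this assay compound 2 gives 7300 nM. Among the three, compound 2 thus stands alone as the one compound whose cytotoxicity could be quantified.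

Compound 4 `COc1cc(NC(C)CCCNC(=O)NNC(=O)Nc2cccc(Cl)c2)c2ncccc2c1` has not yet been measured. It differs from compound 2 in one place: (3-chlorophenyl)amino in place of 2-(4-chlorophenyl)ethenyl on a carbonyl carbon. Within the data shown here, no pair of measured compounds shows such a change, so there is no measured step to lean on.

The expectation is a step toward weaker cytotoxicity, a 4.1-fold higher number from compound 2 to compound 4 (0.61 log units; beyond the scatter), beyond the usual scatter. Compound 4 is therefore estimated to give 30000 nM in this assay, with a plausible range from 7000 nM to 171000 nM.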

Compound 4, half-maximal inhibitory concentration: 58600 nM
Compound 4: middle estimate off by 2.0-fold (0.29 log units), on the low side; the measured number falls inside the stated range.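

Among these compounds, putting (3-chlorophenyl)amino in place of 2-(4-chlorophenyl)ethenyl on a carbonyl carbon gives the first step that can be read at this position, with a change beyond the usual scatter: an 8.0-fold higher number from compound 2 to compound 4 (0.90 log units; beyond the scatter) in this assay. Among the compounds shown here, this shows that the group on this carbonyl carbon matters for cytotoxicity on these cells, which the earlier compounds could not show, since no two of them formed a measured step. The change is not a single small edit, however: the double bond outside the ring leaves, a nitrogen carrying one hydrogen-bond donor enters, and the chlorine changes from the 4-chlorophenyl to the 3-chlorophenyl form, so the step belongs to the whole swap and to no one of these parts.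

A (4-chlorophenyl)amino group on the same carbonyl carbon would keep the new nitrogen while restoring the chlorine of compound 2, and so would help separate these parts. Why the number rises cannot be told, as nothing shown here bears on the cause of this step.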